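Sulfur for oxygen on compound 1: expected tolerance

The compounds below may be only part of what the source reports. "The series", "measured", "known", "first", "only" and "open" are said of these compounds alone.

Values so far in an ADME assay on Vero cells (Chlorocebus sabaeus) for cytotoxicity, read by resazurin assay, with a stated time of 2 days (a higher number here means that more compound is tolerated, a lower number that less compound is tolerated), for two compounds
- compound 1 (`CC(=O)OC[C@H]1O[C@@H](CC(=O)/C=C/c2cccc(NC(=O)Nc3ccccc3)c2)[C@H](OC(C)=O)[C@@H](OC(C)=O)[C@@H]1OC(C)=O`) gives 180000 nM
- compound 2 (`CC(=O)OC[C@H]1O[C@@H](CC(=O)/C=C/c2cccc(NC(=O)Nc3ccccc3)c2)[C@@H](OC(C)=O)[C@@H](OC(C)=O)[C@@H]1OC(C)=O`) gives 102000 nM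

Compound 1 and compound 2 lie within the scatter of each other (a 1.8-fold lower number from compound 1 to compound 2 (0.25 log units; within the scatter)), so compound 1 has no separate standing. Compound 3 (`CC(=O)OC[C@H]1O[C@@H](CC(=O)/C=C/c2cccc(NC(=S)Nc3ccccc3)c2)[C@H](OC(C)=O)[C@@H](OC(C)=O)[C@@H]1OC(C)=O`) differs from compound 1 by a group of 9 heavy atoms (7 carbon, 1 nitrogen, 1 sulfur; one six-membered aromatic ring of carbon only) in place of a group of 9 heavy atoms (7 carbon, 1 nitrogen, 1 oxygen; one six-membered aromatic ring of carbon only), on a nitrogen on an aromatic ring and carries sulfur where oxygen stood. Among the compounds with values here, the sole measured step reflects the fact that compounds 1 and 2 differ only in the configuration as drawn and leaves that group untouched, so it offers no guide to this change. No shift beyond the scatter is expected in this assay, and the expected size is a 1.3-fold lower number from compound 1 to compound 3 (0.11 log units; within the scatter) in this estimate. For compound 3 the estimated value is 140000 nM with an expected range of 50000 nM to 300000 nM in the same read-out.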

Compound 3, half-maximal cytotoxic concentration: 337000 nM
Estimate against measurement, compound 3: 2.4-fold (0.38 log units) below; measured number above the stated range.
By their numbers in this assay, from the lowest: compounds 2, 1 and 3 (each within the scatter of the next, the first and the last beyond it).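

In this assay, sulfur in place of the oxygen of the phenylcarbamoyl group, on a nitrogen on an aromatic ring, gives a 1.9-fold higher number from compound 1 to compound 3 (0.27 log units; within the scatter). At this position, on the core of compound 1, the exchange therefore causes no shift beyond the scatter. No data shown bear on a cause for this step.

Going by these compounds, whether the same exchange gives a similar result on the core of compound 2 remains open. So does the outcome of replacing the phenylcarbamoyl group with an acetyl group or a longer alkyl chain.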